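The source may hold more compounds than are shown below. What is called first, only, known or untested is meant among the compounds shown, and "the series" means these compounds.

In an ADME assay on CCRF-HSB-2 cells (Homo sapiens) for cytotoxicity, with a stated time of 7 days (on this read-out higher numbers stand for lower toxicity in this test and lower numbers for higher toxicity in this test), compound 3 (`CCCCCOc1nc(N)nc2c1ncn2/C=C1/CC1(CO)CO`) gives no number, only a limit of > 20000 nM. Compound 1 (`Nc1nc(NC2CC2)c2ncn(/C=C3/CC3(CO)CO)c2n1`) also gives only a limit, > 20000 nM. Compound 2 (`CC(C)CNc1nc(N)nc2c1ncn2/C=C1/CC1(CO)CO`) is likewise a limit, > 20000 nM. The three compounds therefore share (the limit of > 20000 nM in this assay, at which 3 of the 3 values shown sit).

Compound 4 (`CCCCOc1nc(N)nc2c1ncn2/C=C1/CC1(CO)CO`) differs from compound 3 by hydrogen in place of methyl on a saturated chain carbon, four bonds along the chain from an oxygen on an aromatic ring. For the measured compounds named here, none of the measured steps makes this same change. The closest are those that reach compound 3 with pentyloxy on an aromatic carbon, namely a step that the two limits leave unreadable from compound 1 to compound 3 and a step that the two limits leave unreadable from compound 2 to compound 3. The remaining one, with isobutyl in place of cyclopropyl on a nitrogen on an aromatic ring, is a step that the two limits leave unreadable from compound 1 to compound 2. None of the three has a size that can be read.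

With compound 3 and its two neighbours all resting at the limit of > 20000 nM in this assay, at which 3 of the 3 values shown sit, no change beyond the scatter is expected in this assay, in either direction. The expected step is a step that the limit leaves unreadable from compound 3 to compound 4. Compound 4 is estimated at 25000 nM, with an expected range from 10000 nM to 60000 nM.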

Compound 4, half-maximal cytotoxic concentration: > 20000 nM
Compound 4: no number, only a limit (the forecaster's own chance of this, stated with the estimate: 85%); the middle value lies beyond the limit too.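

Compound 4 also gives only a limit in this assay, so none of the steps to compound 4 from compound 1, compound 2 or compound 3 can be read: the limit of > 20000 nM in this assay, at which 4 of the 4 values shown sit.

The compounds shown leave open how toxic any of the four is to these cells, and whether the groups that differ among them change that toxicity at all.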